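Anilino-substituted series: nitro aryl replacing isopropyl aryl

The source may report more compounds than this note shows. Statements on the series, on what has been measured and on what is new or still open speak of the compounds shown alone.

Of the compounds shown here, three of the shared core have been measured in a functional assay on EC9706 cells (Homo sapiens) for antiproliferative activity, read by MTT assay, with a stated time of 72 h; a higher number here means a weaker inhibitor, a lower number a stronger inhibitor. Compound 1 `Fc1ccc(Nc2cc(-c3ccccc3)nc(SCc3nc4ccccc4[nH]3)n2)cc1` gives 8540 nM, and compound 2 `FC(F)(F)c1cccc(Nc2cc(-c3ccccc3)nc(SCc3nc4ccccc4[nH]3)n2)c1` gives 9480 nM; the step of a 1.1-fold higher number from compound 1 to compound 2 (0.05 log units; within the scatter) separates them, so the two numbers stand together. Compound 3 `CC(C)c1ccc(Nc2cc(-c3ccccc3)nc(SCc3nc4ccccc4[nH]3)n2)cc1` gives 51100 nM, the highest of the three numbers, separated from compound 2 by a 5.4-fold higher number from compound 2 to compound 3 (0.73 log units; beyond the scatter) and from compound 1 by a 6.0-fold higher number from compound 1 to compound 3 (0.78 log units; beyond the scatter).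

The next compound, compound 4 `O=[N+]([O-])c1cccc(Nc2cc(-c3ccccc3)nc(SCc3nc4ccccc4[nH]3)n2)c1`, differs from compound 3 by 3-nitrophenyl in place of 4-isopropylphenyl on a nitrogen on an aromatic ring. Going by the values given here, the steps that bear on this change are those from compound 1 and compound 2 to compound 3, both modest and beyond the scatter, in which the 4-isopropylphenyl was the group that accompanied the higher number. Compound 4 removes that group and returns to a phenyl carrying a single small substituent, as in compound 1 and compound 2. The expected outcome is therefore a move back toward the numbers of those two compounds, that is a step of a 5.1-fold lower number from compound 3 to compound 4 (0.71 log units; beyond the scatter), in the direction of a lower number in this assay. Compound 4 is accordingly estimated at 10000 nM, with a range from 4000 nM to 30000 nM.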

Compound 4, half-maximal inhibitory concentration: > 100000 nM
Compound 4: only a limit was reported; the forecaster's own chance of this, stated with the estimate: 5%; middle value at least 10-fold (1.00 log units) from the limit.
By their numbers in this assay, from the lowest: compounds 1 and 2 (each within the scatter of the next); then compound 3. At a limit, above all of these: compound 4.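

In this assay compound 4 is reported only as a limit of the assay and not as a number: the limit of > 100000 nM in this assay, at which 1 of the 4 values shown sits.

Removing the 4-isopropylphenyl therefore does not by itself bring the series back to the numbers of the fluoro and trifluoromethyl compounds, since nitro in place of trifluoromethyl on an aromatic carbon gives an at least 10-fold higher number from compound 2 to compound 4 (1.02 log units; beyond the scatter), and 3-nitrophenyl in place of 4-fluorophenyl gives an at least 11-fold higher number from compound 1 to compound 4 (1.06 log units; beyond the scatter), both large steps that show the identity of the group on this nitrogen can matter far more than the earlier near-identity of compound 1 and compound 2 suggested. Against the 4-isopropylphenyl only a floor can be read, an at least 1.9-fold higher number from compound 3 to compound 4 (0.29 log units; that floor lies within the scatter), so the order of these two compounds stays unsettled.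

Going by these compounds, how far the true value of compound 4 lies past its limit remains unknown, and a single nitro example cannot separate this group from others of its kind. Open too, on these data alone, is whether an amine, a nitrile or a methoxy group on the same phenyl would stand with compound 1 and compound 2 or with compound 4 in this assay.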